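Cyclopentylmethyl in place of an unsaturated chain: an expectation

The compounds below may be only part of what the source reports. "The series", "measured", "known", "first", "only" and "open" are said of these compounds alone.

Compound 1 `CC(C)=CCOc1cccc(O)c1C(=O)/C=C/c1ccc(O)cc1` gives > 30000 nM in a functional assay on NCI-H23 cells (Homo sapiens) for antiproliferative activity, read by sulforhodamine B assay; on this read-out higher numbers stand for weaker inhibition of growth and lower numbers for stronger inhibition of growth.
Compound 2 `CCCCOc1cccc(O)c1C(=O)/C=C/c1ccc(O)cc1` gives > 30000 nM in this assay.

For compound 1 that value is a limit of the assay, not a number. For compound 2 the value is likewise only a limit. The step that the two limits leave unreadable from compound 1 to compound 2 therefore cannot be read. Compound 3 `O=C(/C=C/c1ccc(O)cc1)c1c(O)cccc1OCCC1CCCC1` differs from compound 1 by cyclopentylmethyl in place of 2-methylprop-1-en-1-yl on a saturated chain carbon bound to an oxygen on an aromatic ring. Among the measured compounds shown here, only that unreadable step bears on this change, so no direction or size beyond the scatter can be expected, and a further limit seems most likely because of the limit of > 30000 nM in this assay, at which 2 of the 2 values shown sit. Compound 3 is estimated at 30000 nM, ranging from 10000 nM to 100000 nM. The expected step is a number no higher from compound 1 to compound 3 (the limit leaves the size open).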

Compound 3, concentration for 50% growth inhibition: 3370 nM
Estimate against measurement, compound 3: 8.9-fold (0.95 log units) above, and the stated range ends above it.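

In this assay, the change at this oxygen-bound chain gives an at least 8.9-fold lower number from compound 1 to compound 3 (0.94 log units; beyond the scatter), and the related change gives an at least 8.9-fold lower number from compound 2 to compound 3 (0.94 log units; beyond the scatter). The earlier compounds shown here showed no readable effect at this place, whereas a chain ending in cyclopentyl brings growth inhibition into measurable range. Compound 3 is the only compound here with an actual number, while the other two values are limits of the assay: the limit of > 30000 nM in this assay, at which 2 of the 3 values shown sit.

As far as these compounds go, both steps start from limits, so their full size stays open. From the compounds shown here alone, it also remains open whether the ring itself matters or only the chain's size, a question that a longer straight chain or a cyclohexyl ring could address.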